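Swapping the Halogenated Aryl on the Acylurea Arm

The source may hold more compounds than are shown below. What is called first, only, known or untested is meant among the compounds shown, and "the series" means these compounds.

Compound 2, with the structure `CN(C(=O)NC(=O)c1ccccc1F)c1nc(C(F)(F)F)c(C(=O)N/N=C/c2cc(C(F)(F)F)cc(C(F)(F)F)c2)s1`, is the stronger of the two numbered results in a functional assay on MCF7 cells (Homo sapiens) for inhibition, read by MTT assay, with a stated time of 72 h (on this read-out higher numbers stand for weaker inhibition and lower numbers for stronger inhibition), where compound 2 gives 6.16 ug/mL. Its nearest neighbour is compound 1, built as `CN(C(=O)NC(=O)c1ccccc1F)c1nc(C(F)(F)F)c(C(=O)N/N=C/c2cccc(C(F)(F)F)c2)s1`, which in this assay gives 20.5 ug/mL; the step of a 3.3-fold lower number from compound 1 to compound 2 (0.52 log units; beyond the scatter) comes from a trifluoromethyl in place of hydrogen on an aromatic carbon. Compound 3, drawn as `CNc1nc(C(F)(F)F)c(C(=O)N/N=C/c2cc(C(F)(F)F)cc(C(F)(F)F)c2)s1`, returns only a limit in this assay, namely > 100 ug/mL.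

The unmeasured compound 4 has the structure `CN(C(=O)NC(=O)c1ccc(Cl)cc1Cl)c1nc(C(F)(F)F)c(C(=O)N/N=C/c2cc(C(F)(F)F)cc(C(F)(F)F)c2)s1`. Compared with compound 2 the change is 2,4-dichlorophenyl in place of 2-fluorophenyl on a carbonyl carbon.

Two measured steps speak to this arm. The step of an at least 16-fold higher number from compound 2 to compound 3 (1.21 log units; beyond the scatter) shows that removing the whole ((2-fluorophenyl)carbonyl)carbamoyl group costs a great deal, so this part of the molecule carries much of the activity. Within the data shown here, no measured step, however, exchanges one aryl for another on that carbonyl carbon. Since the group stays in place and only its halogen pattern shifts, compound 4 is expected to land within the scatter of compound 2, giving an estimated 6.5 ug/mL with a likely range from 2.5 ug/mL to 16 ug/mL. The expected step is therefore a 1.1-fold higher number from compound 2 to compound 4 (0.02 log units; within the scatter).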

Compound 4, half-maximal inhibitory concentration: > 100 ug/mL
Compound 4: no number, only a limit; the forecaster's own chance of this, stated with the estimate: 5%; at least 15-fold (1.18 log units) between middle value and limit.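

Exchanging 2-fluorophenyl for 2,4-dichlorophenyl on the carbonyl carbon gives an at least 16-fold higher number from compound 2 to compound 4 (1.21 log units; beyond the scatter) in this assay, so the aryl group here matters as well as the arm that carries it. Compound 3 had shown only that removing the whole ((2-fluorophenyl)carbonyl)carbamoyl group is costly, whereas compound 4 keeps the same acylurea arm and changes only the halogens on its aryl ring, and activity in this assay still falls sharply. The reading for compound 4 is a limit rather than a number, and it is the same limit that compound 3 reaches: the limit of > 100 ug/mL in this assay, at which 2 of the 4 values shown sit.

With only two aryl groups on this carbonyl carbon, the compounds shown cannot separate the effect of swapping fluorine for chlorine from the effect of having a second halogen on the ring. A 2-chlorophenyl or an unsubstituted phenyl group at this place would help to tell these apart, and a 2,4-difluorophenyl group would show whether two halogens are tolerated when both are fluorine.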